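Removing the nitro group from a chloro-substituted analogue

The compounds below may be only part of what the source reports. "The series", "measured", "known", "first", "only" and "open" are said of these compounds alone.

Measured compounds:
compound 1 `O=C1N/C(=N/c2ccccc2)S/C1=C\c1ccccn1` gives 29.2%
compound 2 `O=C1N/C(=N/c2ccc(Cl)cc2)S/C1=C\c1ccccn1` gives 41.7%
compound 3 `O=C1N/C(=N/c2ccc([N+](=O)[O-])cc2Cl)S/C1=C\c1ccccn1` gives 37.4%

All three numbers come from a functional assay on the whole organism (strain Swiss albino) for inhibition, with Mus musculus as the target, in the writhing test, with stated times of 30 min and 15 min, at a dose of 50 mg/kg by the oral route; a lower number here means less inhibition, a higher number more inhibition at the dose given (going by the name of the read-out). Compound 3 holds the second highest of the three values in this assay; compared with compound 2 its number differs by an amount within the scatter, and compared with compound 1 it also differs by an amount within the scatter, so no order between these three compounds can be asserted from these numbers alone.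

Going by the values given here, the only step between measured compounds that differ in one place is a number 12.5 percentage points higher from compound 1 to compound 2 (beyond the scatter), a modest gain that lies beyond the scatter.

Compound 4 `O=C1N/C(=N/c2ccccc2Cl)S/C1=C\c1ccccn1` differs from compound 3 in one place: hydrogen in place of nitro on an aromatic carbon. Among the compounds with values here, the change leaves the chloro group in place, so the step from compound 1 to compound 2 bears on it only indirectly, and no measured step covers the removal of a nitro group. Within the data shown here, this assay gave a number to every compound so far, so a number rather than a limit is expected for compound 4.

With the chloro group retained and the nitro group gone, compound 4 is expected to sit near compound 3, with an estimated step of a number 2.4 percentage points lower from compound 3 to compound 4 (within the scatter) in this assay. Compound 4 is therefore estimated at 35%, within a range from 22% to 48%.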

Compound 4, a percentage reported as inhibition, in the whole organism at one dose (the size of the read-out at that dose, not a potency): 36.2%
Estimate against measurement, compound 4: 1.2 percentage points below; measured number inside the range.
By their numbers in this assay, from the lowest: compounds 1, 4, 3 and 2 (each within the scatter of the next, the first and the last beyond it).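

In this assay, removing the nitro group while the chloro group stays gives a number 1.2 percentage points lower from compound 3 to compound 4 (within the scatter), so at this dose the two compounds cannot be told apart, and hydrogen and nitro on this aromatic carbon give numbers that lie within the scatter of each other. Going by these compounds alone, the chloro steps add a distinction the earlier compounds could not show: 2-chlorophenyl in place of 4-chlorophenyl gives a number 5.5 percentage points lower from compound 2 to compound 4 (within the scatter), and chloro in place of hydrogen in compound 4 gives a number 7 percentage points higher from compound 1 to compound 4 (within the scatter), whereas only the 4-chlorophenyl step, a number 12.5 percentage points higher from compound 1 to compound 2 (beyond the scatter), lies beyond the scatter. Nothing measured here accounts for these numbers.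

The compounds shown leave open whether an amine, a methoxy group or a carboxylic acid on the aromatic carbon that carried the nitro group would give a number beyond the scatter of compound 4. They also leave open whether the small differences among compound 2, compound 3 and compound 4 would persist at other doses, since each compound is represented here by a single reading at one dose.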